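The source may hold more compounds than are shown below. What is called first, only, known or untested is meant among the compounds shown, and "the series" means these compounds.

Compound 3 `N#CC1=C(N)Oc2c(N)cc3nc4ccccc4nc3c2C12C(=O)N(Cc1cnnn1-c1ccc(Cl)cc1)c1ccccc12` carries a 4-chlorophenyl on the aromatic nitrogen of the shared core. In a functional assay on HCT-116 cells (Homo sapiens) for antiproliferative activity, read by MTT assay, with a stated time of 48 h (on this read-out higher numbers stand for weaker inhibition and lower numbers for stronger inhibition), compound 3 gives > 50000 nM, which is a limit of the assay and not a number. The two other members of the series stand the same way. Compound 1 `N#CC1=C(N)Oc2c(c3nc4ccccc4nc3c3ccccc23)C12C(=O)N(Cc1cnnn1-c1cccc(Cl)c1)c1ccccc12` gives > 50000 nM in this assay, again a limit. Compound 2 `CCOc1ccccc1-n1nncc1CN1C(=O)C2(C(C#N)=C(N)Oc3c2c2nc4ccccc4nc2c2ccccc32)c2ccccc21` gives > 50000 nM in this assay, also a limit. Among the compounds with values here, the sole comparison between measured compounds is a step that the two limits leave unreadable from compound 1 to compound 2, and all three values sit at the limit of > 50000 nM in this assay, at which 3 of the 3 values shown sit.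

Compound 4 `CCOc1ccc(-n2nncc2CN2C(=O)C3(C(C#N)=C(N)Oc4c(N)cc5nc6ccccc6nc5c43)c3ccccc32)cc1` differs from compound 3 by ethoxy in place of chloro on an aromatic carbon. The change resembles the measured step in kind, a chlorophenyl on the aromatic nitrogen becoming an ethoxyphenyl (3-chlorophenyl to 2-ethoxyphenyl there, 4-chlorophenyl to 4-ethoxyphenyl here), and that step had no readable size. No value in the series has yet risen from the limit, so no step beyond the scatter is expected. Compound 4 is therefore expected to remain at the limit, with an estimate of 80000 nM and a range from 30000 nM to 300000 nM. The step this estimate implies, a step that the limit leaves unreadable from compound 3 to compound 4, is expected to be unreadable in the same way.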

Compound 4, half-maximal inhibitory concentration: > 50000 nM
Compound 4: only a limit was reported (the forecaster's own chance of this, stated with the estimate: 85%); the middle value lies beyond the limit too.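

Compound 3 and compound 4 each give only a limit in this assay, so no step between them can be read: the limit of > 50000 nM in this assay, at which 4 of the 4 values shown sit.

The compounds shown leave open what size ethoxy in place of chloro has, and which change to the shared core would give a readable value in this assay.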